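The source may hold more compounds than are shown below. What is called first, only, known or untested is meant among the compounds shown, and "the series" means these compounds.

In a functional assay on BGC-823 cells (Homo sapiens) for inhibition, read by MTT assay, with a stated time of 72 h (on this read-out higher numbers stand for weaker inhibition and lower numbers for stronger inhibition), compound 1 `CCc1cc(N2CC[C@@H](C)[C@@H](N(C)c3ncnc4[nH]ccc34)C2)n2ncnc2n1` gives 82200 nM. Compound 2 `Cc1cc(N2CC[C@@H](C)[C@@H](N(C)c3ncnc4[nH]ccc34)C2)n2nc(SCc3ccc(Cl)cc3)nc2n1`, carrying a 4-chlorophenyl on the saturated chain carbon bound to a sulfur, gives 26300 nM in this assay. For compound 3 `Cc1cc(N2CC[C@@H](C)[C@@H](N(C)c3ncnc4[nH]ccc34)C2)n2nc(SCc3nc4ccccc4[nH]3)nc2n1` this assay reports only a limit, > 100000 nM. Compound 3 thus stands at the weak end of the numbers shown, sitting at the limit of > 100000 nM in this assay, at which 1 of the 3 values shown sits. Within the data shown here, the only measured step bearing on the change followed here is an at least 3.8-fold higher number from compound 2 to compound 3 (0.58 log units; beyond the scatter). Compound 4 `Cc1cc(N2CC[C@@H](C)[C@@H](N(C)c3ncnc4[nH]ccc34)C2)n2nc(SCc3csc4ccc(Cl)cc34)nc2n1` differs from compound 3 by 5-chloro-1-benzothiophen-3-yl in place of 1H-benzimidazol-2-yl on a saturated chain carbon bound to a sulfur. The entering group, like the 4-chlorophenyl of compound 2, carries a chlorine and 0 hydrogen-bond donors, so the measured step is expected to run back the other way. For compound 4 a lower number is expected, a step of an at least 2.8-fold lower number from compound 3 to compound 4 (0.45 log units; beyond the scatter). Compound 4 is estimated at 35000 nM, between 12000 nM and 100000 nM.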

Compound 4, half-maximal inhibitory concentration: > 100000 nM
Compound 4: no number, only a limit; the forecaster's own chance of this, stated with the estimate: 25%; at least 2.8-fold (0.45 log units) between middle value and limit.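

In this assay, 5-chloro-1-benzothiophen-3-yl in place of 4-chlorophenyl on a saturated chain carbon bound to a sulfur gives an at least 3.8-fold higher number from compound 2 to compound 4 (0.58 log units; beyond the scatter). A chlorine and the lack of a hydrogen-bond donor in the entering group are therefore not enough to hold the level of the 4-chlorophenyl group in this series. The step from compound 3 to compound 4 cannot be read, and the values of both are limits, not numbers: the limit of > 100000 nM in this assay, at which 2 of the 4 values shown sit.

Going by these compounds, how far compound 3 and compound 4 lie past that limit stays open. Also open, on these data alone, is how an unsubstituted phenyl, an aliphatic amine or a carboxylic acid would read at this place.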